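The source may report more compounds than this note shows. Statements on the series, on what has been measured and on what is new or still open speak of the compounds shown alone.

Among the compounds with values here, compound 1 `CC(=O)N1CCC(c2ccc3c(c2)oc(=O)n3C(=O)NCCCCc2ccccc2)CC1` is one of three compounds measured in an assay on HEK293 cells for inhibition of acid ceramidase (Homo sapiens), read by fluorescence, with stated times of 10 min and 3 h (on this read-out higher numbers stand for weaker inhibition and lower numbers for stronger inhibition), where compound 1 gives 64 nM. Compound 2 `CN1CCc2oc(=O)n(C(=O)NCCCCc3ccccc3)c2C1` gives 516 nM, and compound 3 `COCCCNC(=O)n1c(=O)oc2cc(-c3ccc(F)cc3)ccc21` gives 2600 nM, so compound 1 stands lowest of the three, with compound 2 the nearest and compound 3 the furthest, both gaps lying beyond the usual scatter. The account now turns to compound 4 `CN1CCC(c2ccc3c(c2)oc(=O)n3C(=O)NCCCCc2ccccc2)CC1`, which differs from compound 1 by methyl in place of acetyl on an amine nitrogen in a ring. Within the data shown here, no measured pair shows this change by itself, so its effect can only be estimated from compound 1. A step expected from compound 1 to compound 4 of a 2.0-fold higher number from compound 1 to compound 4 (0.31 log units; beyond the scatter) in this assay would sit roughly at the edge of the scatter, leaning toward weaker inhibition. Compound 4 is therefore expected to give 130 nM, with a range from 40 nM to 450 nM.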

Compound 4, half-maximal inhibitory concentration: 129 nM
Compound 4: middle estimate off by 1.0-fold (0.00 log units), on the high side; the range from low to high includes it.
By their numbers in this assay, from the lowest: compounds 1 and 4 (each within the scatter of the next); then compound 2; then compound 3.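

In this assay the change at this ring nitrogen gives a 2.0-fold higher number from compound 1 to compound 4 (0.30 log units; within the scatter) and so, on this read-out, the 1-acetylpiperidin-4-yl and 1-methylpiperidin-4-yl compounds cannot be told apart. At this position, the acetyl carbonyl with its hydrogen-bond acceptor can thus be replaced by methyl without a change that can be read. Nothing given here bears on why the two groups read alike. Going by these compounds, what stays open is how a plain hydrogen, a benzyl group or a longer chain on this nitrogen would read. On these data alone, it is also open whether acetyl in place of methyl on the ring nitrogen of compound 2 would leave its number within the scatter.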